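Chain lengthening toward compound 4 in receptor binding

The compounds below may be only part of what the source reports. "The series", "measured", "known", "first", "only" and "open" are said of these compounds alone.

Measured so far:
compound 1, `C=CCc1cc(C(C)=O)c(O)cc1OCCCCC#N`, 92%
compound 2, `C=CCc1cc(C(C)=O)c(O)cc1OCCCCCC#N`, 81%
compound 3, `C=CCc1cc(C(C)=O)c(O)cc1OCCCCCCCC#N`, 88%

Three compounds share one core and differ only in the length of the chain that carries the cyano group. In an assay on isolated protein for inhibition of leukotriene B4 receptor 1 (Homo sapiens), tested at 10 uM (a higher number here means more inhibition at the concentration tested (going by the name of the read-out), a lower number less inhibition), compound 3 gives 88%, the second highest of the three numbers; compound 1 gives 92%, and compound 2 gives 81%. The gap from compound 3 to each neighbour lies within the scatter, so no order among the three can be claimed.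

Compound 4, `C=CCc1cc(C(C)=O)c(O)cc1OCCCCCCCCCCC#N`, has not yet been measured. It differs from compound 3 as follows: 3-cyanopropyl in place of cyano on a saturated chain carbon, seven bonds along the chain from an oxygen on an aromatic ring.

The measured steps that bear on this are all chain lengthenings of the same kind. a number 11 percentage points lower from compound 1 to compound 2 (beyond the scatter), a number 4 percentage points lower from compound 1 to compound 3 (within the scatter), and a number 7 percentage points higher from compound 2 to compound 3 (within the scatter). Only the smallest lengthening moved the number beyond the scatter, and the larger one did not, so lengthening the chain has shown no consistent direction. For the further lengthening to compound 4 a step within the scatter is therefore expected, and compound 4 is estimated at 85%, between 70% and 95%, which means an expected step of a number 3 percentage points lower from compound 3 to compound 4 (within the scatter).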

Compound 4, a percentage reported as inhibition, at one concentration (the size of the read-out at that concentration, not a potency): 50%
Compound 4: middle estimate off by 35 percentage points, on the high side; the measured number lies below the stated range.
By their numbers in this assay, from the lowest: compound 4; then compounds 2, 3 and 1 (each within the scatter of the next, the first and the last beyond it).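

In this assay the chain carrying the nitrile turns out to be sensitive to length after all: the lengthening to compound 4 gives a number 38 percentage points lower from compound 3 to compound 4 (beyond the scatter) and, measured against the shorter chains, a number 31 percentage points lower from compound 2 to compound 4 (beyond the scatter) and a number 42 percentage points lower from compound 1 to compound 4 (beyond the scatter) as well. Among these compounds, compound 4 is therefore the lowest of the four, and the series now shows a limit that the earlier compounds gave no sign of: compounds 1 and 3 stay within the scatter of each other, compound 2 goes against a fully flat picture with its modest step down from compound 1, and only the chain of compound 4 brings a large loss. Nothing available here explains why the number falls at this chain length.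

The compounds shown leave open whether the number falls gradually or abruptly for chains lying in length between those of compound 3 and compound 4, and whether a still longer chain would lower it further. They also leave open whether the loss depends on the nitrile at the chain end, which a carboxylic acid or an amine on the same long chain would address.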